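The source may hold more compounds than are shown below. What is called first, only, known or untested is meant among the compounds shown, and "the series" means these compounds.

Compound 1, `CCC1(Cc2ccccc2)OS(=O)(=O)C=C1OCc1ccc(OC)cc1`, gives >= 200000 nM in an ADME assay on HEL cells (Homo sapiens) for cytotoxicity, with a stated time of 3 days; a higher number here means that more compound is tolerated, a lower number that less compound is tolerated.
Compound 2, `CCC1(Cc2ccccc2)OS(=O)(=O)C=C1OC`, gives > 400000 nM in this assay.

Both values are limits of this assay rather than numbers. Compound 1 sits at the limit of >= 200000 nM in this assay, at which 1 of the 2 values shown sits. Compound 2 sits at the limit of > 400000 nM in this assay, at which 1 of the 2 values shown sits. Going by the values given here, the single step between the measured compounds, a step that the two limits leave unreadable from compound 1 to compound 2, therefore cannot be sized, and compound 2 stands only at its limit. Compound 3, `CCC1(Cc2ccccc2)OS(=O)(=O)C=C1OCCCc1ccccc1`, differs from compound 2 by phenethyl in place of hydrogen on a saturated chain carbon bound to an oxygen on an unsaturated carbon. No readable step bears on this change, so no shift beyond the scatter is expected in either direction. The estimated step is an at least 1.3-fold lower number from compound 2 to compound 3 (0.12 log units; that floor lies within the scatter). For compound 3 the estimate is 300000 nM, between 100000 nM and 400000 nM, and most likely again only a limit is reported.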

Compound 3, minimum cytotoxic concentration: >= 20000 nM
Compound 3 gave a limit, no number; the forecaster's own chance of this, stated with the estimate: 70%; the middle value lies beyond the limit too.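

Going by these compounds alone, compound 1, compound 2 and compound 3 all stand only at limits, so no step among them can be read. Left open is whether phenethyl in place of hydrogen changes the concentration tolerated in this assay at all.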